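Swapping tert-butyl for hydroxy on the benzamide ring

The compounds below may be only part of what the source reports. "The series", "measured", "known", "first", "only" and "open" are said of these compounds alone.

Three hydrazone-type compounds sharing one core have been measured so far. Compound 1 `COc1cc(/C=C/C=N/NC(=O)c2ccc(C(C)(C)C)cc2)ccc1O` gives 20% in a physicochemical assay, read by spectrophotometry, with a stated time of 60 min, tested at 35 uM; on this read-out lower numbers stand for a weaker effect and higher numbers for a stronger effect at the one concentration tested. Compound 2 `COc1ccc(/C=C/C=N/NC(=O)c2ccc(C(C)(C)C)cc2)cc1` gives 6.6% in this assay, and compound 3 `CC(C)(C)c1ccc(C(=O)N/N=C/c2ccc(O)cc2)cc1` gives 10.2% in this assay. Compound 2 stands lowest of the three numbers: it sits within the scatter of compound 3, so no order between those two can be read, while compound 1 lies beyond the scatter above it.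

Compound 4 `COc1ccc(/C=C/C=N/NC(=O)c2ccc(O)cc2)cc1` has not yet been measured. It differs from compound 2 in one place: hydroxy in place of tert-butyl on an aromatic carbon. The change sits on an aromatic carbon of a six-membered aromatic ring of carbon only, para to a large group.

For the measured compounds named here, no measured pair shows this exact exchange, so the size of the step is open. Still, the two compounds that carry a hydroxy have both been measured in this assay: compound 1 gives 20%, which lies beyond the scatter above compound 2, and compound 3 gives 10.2%, which sits within the scatter of compound 2. A modest upward step is therefore expected, probably near the edge of the scatter rather than far beyond it, and the expected step is a number 7.4 percentage points higher from compound 2 to compound 4 (within the scatter). Compound 4 is estimated at 14% in this assay, with a likely range from 5% to 28%.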

Compound 4, a percentage reported as inhibition, at one concentration (the size of the read-out at that concentration, not a potency): 3.4%
Estimate against measurement, compound 4: 10.6 percentage points above; measured number outside the range, below it.
By their numbers in this assay, from the lowest: compounds 4, 2, 3 and 1 (each within the scatter of the next, the first and the last beyond it).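

In this assay, for the compounds shown here, putting hydroxy in place of tert-butyl on an aromatic carbon para to a large group gives a number 3.2 percentage points lower from compound 2 to compound 4 (within the scatter), the first direct reading of this exchange at this position. In this one pair, then, 4 carbon atoms can leave and 1 oxygen can enter, bringing 1 hydrogen-bond donor and 1 hydrogen-bond acceptor, without a shift that can be told apart from the usual scatter of repeated measurements. No separate measurement bears on why the read-out stays within the scatter here.

One pair at one concentration cannot show whether the same exchange would also stay within the scatter on the core of compound 1 or of compound 3, which differ from compound 4 in more than one place and so cannot be set directly against it. As far as these compounds go, it also remains open whether another group at this position, such as an amine, a carboxylic acid or a longer chain, would produce a step beyond the scatter in this assay or would likewise leave the number within it.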